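Dimethylamino replaces isobutylamino on the pyrimidine-linked urea

A few compounds are considered here, and "the series" means these few. Any claim that something is new, unique, unknown or untested is made for them only; others in the source may bear on it.

Measured so far in an assay on isolated protein for inhibition of serine/threonine-protein kinase TNNI3K (Homo sapiens); on this read-out lower numbers stand for stronger inhibition and higher numbers for weaker inhibition:
compound 1 `O=C(Nc1ccc(Oc2ccncn2)cc1)Nc1cccc(C(F)(F)F)c1` gives 160 nM;
compound 2 `CC(C)CNc1cc(Oc2ccc(NC(=O)Nc3cccc(C(F)(F)F)c3)cc2)ncn1` gives 50 nM.

Compound 2 holds the lowest number of the two, with compound 1 next. The step from compound 1 to compound 2 was a 3.2-fold lower number from compound 1 to compound 2 (0.51 log units; beyond the scatter), a modest gain. Compound 3 `CN(C)c1cc(Oc2ccc(NC(=O)Nc3cccc(C(F)(F)F)c3)cc2)ncn1` differs from compound 2 by dimethylamino in place of isobutylamino on an aromatic carbon. Within the data shown here, no measured step covers a change between two amino groups; only the gain from adding the larger amino group bears on it. Compound 3 is therefore expected to fall between compound 1 and compound 2, a step of a 1.8-fold higher number from compound 2 to compound 3 (0.26 log units; within the scatter), estimated at 90 nM within 40 nM to 250 nM.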

Compound 3, half-maximal inhibitory concentration: 2500 nM
Beside the measured number, compound 3's estimate is 28-fold (1.44 log units) below it; the whole stated range lies below it.
By their numbers in this assay, from the lowest: compound 2; then compound 1; then compound 3.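

Replacing isobutylamino with dimethylamino gives a 50-fold higher number from compound 2 to compound 3 (1.70 log units; beyond the scatter) in this assay, and dimethylamino in place of hydrogen gives a 16-fold higher number from compound 1 to compound 3 (1.19 log units; beyond the scatter), so an amino group at this position does not lower the number by itself. Relative to hydrogen, the two amino groups move the number in opposite directions. The change also drops the hydrogen-bond donor and shortens the substituent, but no measurement here explains the loss.

The compounds shown leave open which of these two differences matters. Methylamino, which keeps the amine hydrogen, and diethylamino, which lacks it, would help to separate them.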